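The source may report more compounds than this note shows. Statements on the series, on what has been measured and on what is new or still open speak of the compounds shown alone.

Measured so far:
- compound 1, `CC[C@@H](Nc1c(C#N)c(-c2ccc(-c3cccnc3C)cc2)nc2cnccc12)C(N)=O`: 1.9
- compound 2, `CCOc1ccccc1-c1ccc(-c2nc3cnccc3c(N[C@@H]3CCOC3=O)c2C#N)cc1`: 2.7

In a physicochemical assay for lipophilicity, read by HPLC, at pH 7.5 (on this read-out higher numbers stand for higher lipophilicity and lower numbers for lower lipophilicity), compound 1 gives 1.9 and compound 2 gives 2.7. Compound 2 therefore stands at the higher of the two values, and its gap to compound 1 lies beyond the scatter of this assay. The two compounds differ in more than one place, so nothing is drawn from that gap beyond what the two numbers themselves show.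

Compound 3, `CCOc1ccccc1-c1ccc(-c2nc3cnccc3c(N[C@H](CC)C(=O)NS(C)(=O)=O)c2C#N)cc1`, is not yet measured. It keeps the ethoxyphenyl side of compound 2 and changes the group on the nitrogen: a group of 10 heavy atoms (5 carbon, 1 nitrogen, 3 oxygen, 1 sulfur; no ring) in place of a group of 6 heavy atoms (4 carbon, 2 oxygen; one five-membered non-aromatic ring with 1 hetero atom), on a nitrogen on an aromatic ring

Among the compounds with values here, no measured pair changes that position alone, so the size of the step can only be judged from the change itself. The expectation is a fall in this assay from compound 2 to compound 3, of a size well beyond the scatter, written as a number 1.50 log units lower from compound 2 to compound 3 (beyond the scatter). For compound 3 the estimate in this assay is 1.2, with a range from 0.4 to 2.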

Compound 3, distribution coefficient: 2.2
Estimate against measurement, compound 3: 1.00 log units below, outside the stated range (above it).
By their numbers in this assay, from the lowest: compounds 1 and 3 (each within the scatter of the next); then compound 2.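

In this assay, the change on a nitrogen on an aromatic ring can now be read on its own, with the ethoxyphenyl side held: a number 0.50 log units lower from compound 2 to compound 3 (beyond the scatter). The 2-oxooxolan-3-yl group gives way to an open group with no ring, of 10 heavy atoms and with 1 hydrogen-bond donor where the leaving group has 0, and the read-out moves by a modest step that still lies beyond the scatter, so this position does register in this assay. No measurement available here bears on which part of the change lies behind that step.

Within the data shown here, the single step leaves the loss of the ring and the gain of the sulfur-containing group unseparated, and an open chain ending in a carboxylic acid on the same nitrogen, with the ethoxyphenyl side held, would show how far the step depends on that end of the group. Among these compounds, compound 1 differs from compound 2 and from compound 3 in more than one place, so no step to it can be read, and the effect of the ethoxyphenyl side on this read-out remains open.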